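The compounds below may be only part of what the source reports. "The series", "measured", "known", "first", "only" and "open" are said of these compounds alone.

The measured compounds, in a functional assay on HepG2 cells (Homo sapiens) for cytotoxicity, read by MTT assay, with a stated time of 72 h; on this read-out higher numbers stand for weaker inhibition and lower numbers for stronger inhibition:

compound 1, `CNC(=O)c1cc(Oc2ccc(/C=C/C(=O)c3ccc([N+](=O)[O-])cc3)cc2)ccn1`: 41400 nM
compound 2, `CNC(=O)c1cc(Oc2ccc(C(=O)/C=C/c3ccc(F)cc3Cl)cc2)ccn1`: 7320 nM
compound 3, `CNC(=O)c1cc(Oc2ccc(/C=C/C(=O)c3ccc(Cl)cc3)cc2)ccn1`: 36600 nM

Compound 2 gives the lowest of the three numbers, and its gap to each of the other two lies beyond the scatter, so on these numbers compound 2 is the strongest inhibitor of the three. Compound 1 and compound 3, in contrast, differ from one another by a 1.1-fold lower number from compound 1 to compound 3 (0.05 log units; within the scatter), a chloro-for-nitro exchange on an aromatic carbon that leaves the read-out essentially unchanged.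

Compound 4, `CNC(=O)c1cc(Oc2ccc(C(=O)/C=C/c3ccc(Cl)cc3Cl)cc2)ccn1`, is related to compound 2 by a single change: chloro in place of fluoro on an aromatic carbon. Going by the values given here, no measured pair shows this exact exchange, so the only guidance is indirect. Among the compounds with values here, the one step that bears on it at all, the halogen-for-nitro swap from compound 1 to compound 3, was within the scatter, which suggests that a small substituent exchange on this outer aromatic ring need not shift the number much. On that basis the expectation for compound 4 in this assay is a step of about a 1.1-fold lower number from compound 2 to compound 4 (0.05 log units; within the scatter), that is, no change beyond the scatter in either direction. The estimated value for compound 4 is therefore 6500 nM, expected to lie between 2500 nM and 16000 nM.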

Compound 4, half-maximal inhibitory concentration: 11700 nM
The estimate for compound 4 lay 1.8-fold (0.26 log units) below the measured number, and the stated range covers the measured number.
By their numbers in this assay, from the lowest: compounds 2 and 4 (each within the scatter of the next); then compounds 3 and 1 (each within the scatter of the next).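

Moving from the 2-chloro-4-fluorophenyl to the 2,4-dichlorophenyl group, in this assay, gives a 1.6-fold higher number from compound 2 to compound 4 (0.20 log units; within the scatter). Going by these compounds alone, this is the first direct reading of fluoro against chloro at this position, on an aromatic carbon meta to a chloro group and para to a large group; the only earlier step concerned nitro and chloro in compounds whose linker differs from that of compound 2, and it did not bear on this exchange directly. At this position, the read-out does not separate the two halogens, so compound 2 and compound 4 cannot be placed in an order on these numbers, and nothing available accounts for how closely they agree.

The compounds shown leave open whether a group of a different kind at this position, such as a methoxy group, an amine or a carboxylic acid, would shift the number beyond the scatter. Within the data shown here, they also leave open what the chloro group shared by compound 2 and compound 4 contributes, as no compound here carries a hydrogen or a methyl group in its place.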